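The source may report more compounds than this note shows. Statements on the series, on what has been measured and on what is new or still open speak of the compounds shown alone.

Working notes on the series in a functional assay on PC-3 cells (Homo sapiens) for cytotoxicity, read by MTT assay, with a stated time of 72 h; on this read-out higher numbers stand for weaker inhibition and lower numbers for stronger inhibition.

Compound 1 `CC1=C(/C=C/C(=O)/C=C/c2ccccc2F)C(C)(C)CCC1` gives 22100 nM in this assay. Compound 2 `CC1=C(/C=C/C(=O)/C=C/c2ccc(F)cc2)C(C)(C)CCC1` gives 25800 nM. Compound 3 `CC1=CCCC(C)(C)C1/C=C/C(=O)/C=C/c1cccc(C(F)(F)F)c1` gives 5200 nM. Compound 2 stands at the highest number of the three, within the scatter of compound 1 and well apart from compound 3, which shows the lowest number of the set. Going by the values given here, the single step measured within the set, a 1.2-fold higher number from compound 1 to compound 2 (0.07 log units; within the scatter), moves the fluorine around the phenyl ring and leaves the number essentially unchanged.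

Compound 4 `CC1=C(/C=C/C(=O)/C=C/c2ccc(F)cc2)C(C)(C)CCC1O` differs from compound 2 by hydroxy in place of hydrogen on a saturated ring carbon. Among the compounds with values here, no measured step touches the saturated part of the core; the one step that exists, a 1.2-fold higher number from compound 1 to compound 2 (0.07 log units; within the scatter), concerns the aryl ring and so does not bear on this change. With nothing to draw on, the working expectation for compound 4 is a step of a 1.1-fold lower number from compound 2 to compound 4 (0.03 log units; within the scatter), that is no movement beyond the scatter, and the expected value for compound 4 is estimated at 24000 nM within a range of 8000 nM to 70000 nM.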

Compound 4, half-maximal inhibitory concentration: 6200 nM
Compound 4: the middle estimate sits 3.9-fold (0.59 log units) above what was measured, outside the stated range (below it).
By their numbers in this assay, from the lowest: compounds 3 and 4 (each within the scatter of the next); then compounds 1 and 2 (each within the scatter of the next).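

In this assay, going by these compounds alone, hydroxy in place of hydrogen on a saturated ring carbon gives a 4.2-fold lower number from compound 2 to compound 4 (0.62 log units; beyond the scatter) and so lies beyond the scatter, whereas the only earlier step, on the aryl ring, stayed within it. Within the data shown here, this is the first measured change on the saturated part of the core, and it shows that this ring carbon, next to the ring atom that bears a methyl group, is a place where a substitution moves the number towards stronger inhibition, at least with the 4-fluorophenyl group present. No measured information bears on the origin of this step, so it remains unexplained.

From the compounds shown here alone, it remains open whether the step is particular to hydroxy or would also appear with a methoxy group, an amine or a carbonyl on the same carbon. Going by these compounds, it is equally open whether hydroxy at this place gives a comparable step alongside the 2-fluorophenyl group of compound 1 or the trifluoromethyl-bearing aryl ring of compound 3.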